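The source may hold more compounds than are shown below. What is called first, only, known or untested is meant among the compounds shown, and "the series" means these compounds.

Of the compounds shown here, three sharing one core have been tested in a functional assay on MCF7 cells (Homo sapiens) for antiproliferative activity, read by MTT assay, with a stated time of 72 h; a higher number here means a weaker inhibitor, a lower number a stronger inhibitor. Compound 1 `N#Cc1ccc(/C=N/NC(=O)Nc2ccc(Oc3ccnc4[nH]ccc34)c(F)c2)cc1` gives "not active" (no number reported), and compound 2 `O=C(N/N=C/c1cccc([N+](=O)[O-])c1)Nc1ccc(Oc2ccnc3[nH]ccc23)c(F)c1` gives "not active" (no number reported). Among the compounds with values here, compound 3 `O=C(N/N=C/c1ccc([N+](=O)[O-])cc1)Nc1ccc(Oc2ccnc3[nH]ccc23)c(F)c1` gives 4000 nM, the only number among the three. Compound 4 `COc1ccc(/C=N/NC(=O)Nc2ccc(Oc3ccnc4[nH]ccc34)c(F)c2)cc1` changes one group of compound 3: methoxy in place of nitro on an aromatic carbon, so that 4-nitrophenyl becomes 4-methoxyphenyl. Within the data shown here, no measured pair shows what this swap does, so the guidance is thin. Compound 2, at "not active" (no number reported), tilts the expectation toward the weak side. A modest move toward weaker inhibition is expected in this assay, an estimated 2.3-fold higher number from compound 3 to compound 4 (0.35 log units; beyond the scatter). For compound 4 the estimated value is 9000 nM, with an expected range from 3000 nM to 30000 nM.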

Compound 4, half-maximal inhibitory concentration: 5750 nM
For compound 4 the middle estimate is 1.6-fold (0.19 log units) above the measured one, within the range that was stated.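

In this assay the change from 4-nitrophenyl to 4-methoxyphenyl gives a 1.4-fold higher number from compound 3 to compound 4 (0.16 log units; within the scatter) and so leaves the reading essentially unchanged, which shows that this place on the ring can carry either group and still give a number. Compound 1, with a nitrile at the same place, gives "not active" (no number reported) in the same test, so a number is not assured for every group there. Nothing measured here explains why the nitro and methoxy compounds read alike.

As far as these compounds go, how an amine or a carboxylic acid at this place would read remains open.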